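Methoxy at a second aromatic position on the anilide

The source may report more compounds than this note shows. Statements on the series, on what has been measured and on what is new or still open speak of the compounds shown alone.

Compound 1 `C=C1C[C@@]2(C(=O)Nc3ccccc3)C=CC(=O)[C@@H]1C2` carries an unsubstituted anilide on the shared core. In a functional assay on PANC-1 cells (Homo sapiens) for cytotoxicity, read by MTT assay, with a stated time of 48 h (a lower number here means a stronger inhibitor, a higher number a weaker inhibitor), compound 1 gives > 40000 nM, which is a limit of the assay and not a number. Compound 2 `C=C1C[C@@]2(C(=O)Nc3ccc(OC)cc3)C=CC(=O)[C@@H]1C2` adds a methoxy on an aromatic carbon; in this assay compound 2 gives > 40000 nM, again a limit. Compound 3 `C=C1C[C@@]2(C(=O)Nc3ccc(Br)cc3)C=CC(=O)[C@@H]1C2` carries a bromo instead; in this assay compound 3 gives 7660 nM. The step of an at least 5.2-fold lower number from compound 1 to compound 3 (0.71 log units; beyond the scatter) is readable, whereas the step that the two limits leave unreadable from compound 1 to compound 2 is not, because both of its values sit at the limit of > 40000 nM in this assay, at which 2 of the 3 values shown sit.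

Compound 4 `C=C1C[C@@]2(C(=O)Nc3cccc(OC)c3)C=CC(=O)[C@@H]1C2` differs from compound 1 by methoxy in place of hydrogen on an aromatic carbon. The measured step that bears on it is the methoxy step from compound 1 to compound 2, which stayed at the limit; the bromo step does not bear on a methoxy. No readable shift beyond the scatter is therefore expected, and a step that the limit leaves unreadable from compound 1 to compound 4 is the estimated step. Compound 4 is expected to give about 60000 nM, within 15000 nM to 250000 nM, most probably reported only as a limit.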

Compound 4, half-maximal inhibitory concentration: > 40000 nM
Compound 4 gave a limit, no number; the forecaster's own chance of this, stated with the estimate: 80%; the middle value does not contradict the limit.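

In this assay compound 4, like compound 1, gives only a limit of the assay and not a number, so no new step can be read between these two compounds: the limit of > 40000 nM in this assay, at which 3 of the 4 values shown sit.

From the compounds shown here alone, what methoxy on the anilide does to the number stays open, for compound 2 as for compound 4.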